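Nitro group placement on a sulfonyl-linked anticancer scaffold

The source may hold more compounds than are shown below. What is called first, only, known or untested is meant among the compounds shown, and "the series" means these compounds.

In a functional assay on HL-60 cells (Homo sapiens) for inhibition, read by CCK-8 assay, with a stated time of 48 h, tested at 20 uM (on this read-out lower numbers stand for less inhibition of growth and higher numbers for more inhibition of growth at the one concentration tested), three compounds have been measured:
compound 1 `N#C/C(=C\c1ccccc1OS(=O)(=O)c1ccc([N+](=O)[O-])cc1)C(=O)Nc1nnc(Cc2cccc3ccccc23)s1` gives 18%;
compound 2 `N#C/C(=C\c1ccccc1OS(=O)(=O)c1ccccc1[N+](=O)[O-])C(=O)Nc1nnc(Cc2cccc3ccccc23)s1` gives 23%;
compound 3 `N#C/C(=C\c1ccccc1OS(=O)(=O)c1ccc([N+](=O)[O-])cc1)C(=O)Nc1nnc(Cc2ccccc2)s1` gives 20%.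

Compound 2 differs from compound 1 by 2-nitrophenyl in place of 4-nitrophenyl on a sulfonyl sulfur, and this gave a number 5 percentage points higher from compound 1 to compound 2 (within the scatter). Compound 3 differs from compound 1 in its core by phenyl in place of naphthalen-1-yl on a saturated chain carbon bound to an aromatic carbon, with a number 2 percentage points higher from compound 1 to compound 3 (within the scatter). All three numbers sit close together, so none can be called stronger than another.

Compound 4 `N#C/C(=C\c1ccccc1OS(=O)(=O)c1ccccc1[N+](=O)[O-])C(=O)Nc1nnc(Cc2ccccc2)s1` is not yet measured. It differs from compound 3 by 2-nitrophenyl in place of 4-nitrophenyl on a sulfonyl sulfur, the same change already seen from compound 1 to compound 2, at the same place. In this assay the step from compound 3 to compound 4 is expected to be a number 5 percentage points higher from compound 3 to compound 4 (within the scatter), resting on the small step of a number 5 percentage points higher from compound 1 to compound 2 (within the scatter). For compound 4 the estimate is therefore 25%, between 13% and 37%.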

Compound 4, percent growth inhibition at one concentration: 12%
Compound 4: middle estimate off by 13 percentage points, on the high side, and the stated range ends above it.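

Putting 2-nitrophenyl in place of 4-nitrophenyl on the sulfonyl sulfur gave a number 8 percentage points lower from compound 3 to compound 4 (within the scatter), and this cannot be separated from the same change on the other core: the same change on two cores in this assay, a number 5 percentage points higher (within the scatter) from compound 1 to compound 2 and a number 8 percentage points lower (within the scatter) from compound 3 to compound 4, 13 percentage points apart, within the scatter of two such steps. Phenyl in place of naphthalen-1-yl gave a number 11 percentage points lower from compound 2 to compound 4 (beyond the scatter), a modest step beyond the scatter, yet it also cannot be separated from its earlier counterpart: the same change on two cores in this assay, a number 2 percentage points higher (within the scatter) from compound 1 to compound 3 and a number 11 percentage points lower (beyond the scatter) from compound 2 to compound 4, 13 percentage points apart, within the scatter of two such steps. These comparisons give no firm sign that either change depends on the core, but they also do not show that either change keeps its size from one core to another.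

Going by these compounds, it remains open what an amine in place of the nitro group would do. The same holds for a carboxylic acid on the phenyl ring.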